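Pyrazolopyrimidine series: swapping the ring substituent for isopropyl

A few compounds are considered here, and "the series" means these few. Any claim that something is new, unique, unknown or untested is made for them only; others in the source may bear on it.

Measured compounds:
Compound 1 `Cc1cc(Nc2nc(NCc3ccc(F)cc3F)nc3[nH]ncc23)n[nH]1` — 2670 nM
Compound 2 `Cc1cc(Nc2nc(NCc3ccc(F)cc3F)nc3c2cnn3C2CCOCC2)n[nH]1` — 2880 nM

In a functional assay on MDA-MB-231 cells (Homo sapiens) for inhibition, read by MTT assay, with a stated time of 5 days (on this read-out lower numbers stand for stronger inhibition and higher numbers for weaker inhibition), compound 1 gives 2670 nM and compound 2 gives 2880 nM. Among the compounds with values here, compound 2 holds the highest of the two numbers, its nearest neighbour being compound 1; the single measured step, a 1.1-fold higher number from compound 1 to compound 2 (0.03 log units; within the scatter), shows that hydrogen and oxan-4-yl on the aromatic nitrogen cannot be told apart on this read-out.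

The next compound, compound 3 `Cc1cc(Nc2nc(NCc3ccc(F)cc3F)nc3c2cnn3C(C)C)n[nH]1`, is not yet measured. It differs from compound 2 by isopropyl in place of oxan-4-yl on an aromatic nitrogen. Within the data shown here, the one step that bears on this change is a 1.1-fold higher number from compound 1 to compound 2 (0.03 log units; within the scatter), which shows that a substituent at this aromatic nitrogen, at least in the case of oxan-4-yl, leaves the number where it was. Nothing measured separates a ring-bearing substituent from a chain at this place, so the expected step of a 1.1-fold lower number from compound 2 to compound 3 (0.04 log units; within the scatter) is small and of no settled direction. For compound 3 the number expected in this assay is 2600 nM, with a range from 1100 nM to 6000 nM.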

Compound 3, half-maximal inhibitory concentration: 5350 nM
Beside the measured number, compound 3's estimate is 2.1-fold (0.31 log units) below it; the measured number falls inside the stated range.
By their numbers in this assay, from the lowest: compounds 1, 2 and 3 (each within the scatter of the next).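

In this assay, a group without a ring can now be set against one at this aromatic nitrogen: the step for isopropyl in place of oxan-4-yl, with its ring and hydrogen-bond acceptor gone, is a 1.9-fold higher number from compound 2 to compound 3 (0.27 log units; within the scatter) and stays within the scatter. Compound 3 also adds the comparison of isopropyl with hydrogen at the same place, a 2.0-fold higher number from compound 1 to compound 3 (0.30 log units; within the scatter), which is likewise within the scatter, so hydrogen, oxan-4-yl and isopropyl cannot be told apart here, and neither the ring nor the oxygen of oxan-4-yl is shown to be needed to hold the number. No independent measurement is available that could bear on these numbers.

The three compounds leave open whether a piperidin-4-yl group with its ring amine, a carboxylic acid on a short chain or a longer alkyl chain at this aromatic nitrogen would also fall within the scatter of these values. They also leave open whether this insensitivity to the substituent on the aromatic nitrogen would persist if another part of the shared core were changed, since everything else is held constant across compounds 1, 2 and 3.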